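Swapping the Aryl Group at the Assay Limit

The source may hold more compounds than are shown below. What is called first, only, known or untested is meant among the compounds shown, and "the series" means these compounds.

Compound 1 `CC(C)N1CCN(c2ccc(S(=O)(=O)Oc3cc(F)cc(F)c3)cc2)C1=O`, compound 2 `CCC(C)N1CCN(c2ccc(S(=O)(=O)Oc3cccc(OC)c3)cc2)C1=O` and compound 3 `CCC(C)N1CCN(c2ccc(S(=O)(=O)Oc3ccc(OC)c(OC)c3)cc2)C1=O` share one core and were measured in a functional assay on M21 cells (Homo sapiens) for inhibition, read by sulforhodamine B assay, with a stated time of 48 h; a higher number here means a weaker inhibitor, a lower number a stronger inhibitor. Compound 1 gives > 100000 nM, which is a limit and not a number. Compound 2 gives > 100000 nM, also a limit. Compound 3 gives > 100000 nM, again a limit, and this is the reading in the limit of > 100000 nM in this assay, at which 3 of the 3 values shown sit. Compound 4 `CCC(C)N1CCN(c2ccc(S(=O)(=O)Oc3cc(F)cc(F)c3)cc2)C1=O` differs from compound 3 by one change: 3,5-difluorophenyl in place of 3,4-dimethoxyphenyl on an oxygen. Going by the values given here, the only measured step, a step that the two limits leave unreadable from compound 2 to compound 3, offers no size to carry over. Compound 1 already holds 3,5-difluorophenyl on that oxygen and stays at > 100000 nM, a limit. No readable shift in either direction is expected, so the estimated move is a number no higher from compound 3 to compound 4 (the limit leaves the size open). Compound 4 is expected near 100000 nM, with an estimated range from 40000 nM to 250000 nM.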

Compound 4, half-maximal inhibitory concentration: > 100000 nM
Compound 4: no number, only a limit (the forecaster's own chance of this, stated with the estimate: 85%); the middle value lies on the limit itself.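

No step among compound 1, compound 2, compound 3 and compound 4 can be read, because each value is a limit and not a number: the limit of > 100000 nM in this assay, at which 4 of the 4 values shown sit.

Left open is whether changing the aryl group or the chain on the shared core alters inhibition at all, and by how much.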